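Removing the nitro group from compound 1: what to expect

The source may hold more compounds than are shown below. What is called first, only, known or untested is meant among the compounds shown, and "the series" means these compounds.

Within the data shown here, compound 1 `CCCCCNc1oc2c(C)ncc(CO)c2c1Nc1cccc([N+](=O)[O-])c1` is the only member of the series with a numeric result in a functional assay on HEK293 cells for agonist activity at Toll-like receptor 8 (Homo sapiens), read by reporter gene assay (a lower number here means that less compound is needed, a higher number that more compound is needed for the effect), so far: compound 1 gives 850 nM. Compound 2 `CCOC(=O)CNc1oc2c(C)ncc(CO)c2c1Nc1ccccn1` carries a different chain and a different aryl group, and in this assay compound 2 gives "not active" (no number reported). Among the measured compounds shown here, no step between two measured compounds that differ in a single place has been recorded, so compound 1 stands alone as the reference point.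

Compound 3 `CCCCCNc1oc2c(C)ncc(CO)c2c1Nc1ccccc1` differs from compound 1 by one change: hydrogen in place of nitro on an aromatic carbon. With no measured neighbour for comparison, the expected step is a modest loss, roughly from compound 1 to compound 3 a 1.8-fold higher number from compound 1 to compound 3 (0.25 log units; within the scatter), but it could also fall within the scatter. The estimated value for compound 3 in this assay is 1500 nM, with a range from 500 nM to 5000 nM.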

Compound 3, half-maximal effective concentration: 2250 nM
Estimate against measurement, compound 3: 1.5-fold (0.18 log units) below; measured number inside the range.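

This gives the series its first comparison across a single place in this assay: hydrogen in place of nitro, or 3-nitrophenyl to phenyl, gives a 2.6-fold higher number from compound 1 to compound 3 (0.42 log units; beyond the scatter), a modest step that lies beyond the scatter. The nitro group is therefore not required for a numeric result, as compound 3 still gives 2250 nM, but its removal does shift the number at this position. No measurement on hand accounts for the size of this step.

Still open, on these data alone, is whether the shift is specific to nitro, or whether a nitrile, an amine or a carboxylic acid at the same place would give a number closer to that of compound 1 or compound 3. Among these compounds, also open is whether a longer chain in place of the one on compound 1 would leave this step unchanged.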